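Thiophene substituent change and cytotoxicity in one series

The compounds below may be only part of what the source reports. "The series", "measured", "known", "first", "only" and "open" are said of these compounds alone.

Measured compounds:
compound 1, `Cc1csc(C2=NNC(c3ccc(N4CCCCC4)cc3)C2)c1`: 24400 nM
compound 2, `Clc1ccc(C2=NNC(c3ccc(N4CCCCC4)cc3)C2)s1`: > 100000 nM, a limit of the assay, not a number
compound 3, `Clc1cc(C2=NNC(c3ccc(N4CCCCC4)cc3)C2)c(Cl)s1`: 59000 nM

In an ADME assay on PBMC cells (Homo sapiens) for cytotoxicity, with a stated time of 5 days (a higher number here means a weaker inhibitor, a lower number a stronger inhibitor), compound 3 gives 59000 nM, the higher of the two plain numbers shown. The nearest plain number is one modest step away: a 2.4-fold higher number from compound 1 to compound 3 (0.38 log units; beyond the scatter). Compound 4, `Ic1ccc(C2=NNC(c3ccc(N4CCCCC4)cc3)C2)s1`, differs from compound 3 by 5-iodothiophen-2-yl in place of 2,5-dichlorothiophen-3-yl on a carbon with a double bond to nitrogen. Among the compounds with values here, two measured steps bear on this change: an at least 4.0-fold higher number from compound 1 to compound 2 (0.61 log units; beyond the scatter), which exchanged a methyl-bearing thiophene for a halogen-bearing thiophen-2-yl and went beyond the scatter, and an at least 1.6-fold lower number from compound 2 to compound 3 (0.22 log units; that floor lies within the scatter), whose floor lies within the scatter. Compound 4 carries a halogen-bearing thiophen-2-yl like compound 2, so a somewhat higher number is expected, a 1.4-fold higher number from compound 3 to compound 4 (0.16 log units; within the scatter). The value of compound 2 is a limit, (the limit of > 100000 nM in this assay, at which 1 of the 3 values shown sits), so compound 4 may likewise only reach a limit. For compound 4 the estimate is 85000 nM, with a range from 30000 nM to 250000 nM.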

Compound 4, half-maximal inhibitory concentration: > 100000 nM
Compound 4: only a limit was reported; the forecaster's own chance of this, stated with the estimate: 45%; middle value at least 1.1-fold (0.07 log units) away from the limit.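

In this assay, compound 4 also ends at a limit of the assay, not a number, as compound 2 does: the limit of > 100000 nM in this assay, at which 2 of the 4 values shown sit.

Against 4-methylthiophen-2-yl, 5-iodothiophen-2-yl gives an at least 4.0-fold higher number from compound 1 to compound 4 (0.61 log units; beyond the scatter), so iodo matches the direction seen with chloro. Against 2,5-dichlorothiophen-3-yl it gives an at least 1.6-fold higher number from compound 3 to compound 4 (0.22 log units; that floor lies within the scatter), which does not separate the two groups. The step from chloro to iodo cannot be read: both values are limits.

Going by these compounds, whether a thiophene carrying an amine or a carboxylic acid in place of the halogen would give a plain number stays open.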